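The compounds below may be only part of what the source reports. "The series", "measured", "known", "first", "only" and "open" are said of these compounds alone.

Working notes on the series. Compound 1 `CCCc1ccc(-c2c(C)[nH]c(=O)n2C)cc1`, compound 2 `Cc1[nH]c(=O)n(C)c1-c1ccc(CC(C)C)cc1` and compound 3 `CCCCCCOc1ccc(-c2c(C)[nH]c(=O)n2C)cc1` have been measured in a functional assay on brain (Rattus norvegicus, strain Wistar) for inhibition; a higher number here means a weaker inhibitor, a lower number a stronger inhibitor. Compound 1 gives 21500 nM, compound 2 gives 7800 nM and compound 3 gives 7300 nM in this assay.

The change from compound 1 to compound 2 is methyl in place of hydrogen on a saturated chain carbon bound to two saturated chain carbons and gives a 2.8-fold lower number from compound 1 to compound 2 (0.44 log units; beyond the scatter). The cores of compound 1 and compound 3 differ by hexyloxy in place of propyl on an aromatic carbon, which gives a 2.9-fold lower number from compound 1 to compound 3 (0.47 log units; beyond the scatter). Between compound 2 and compound 3 the step is a 1.1-fold lower number from compound 2 to compound 3 (0.03 log units; within the scatter).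

Compound 4 `CCCCCCCOc1ccc(-c2c(C)[nH]c(=O)n2C)cc1` has not been measured. It differs from compound 3 by methyl in place of hydrogen on a saturated chain carbon, six bonds along the chain from an oxygen on an aromatic ring. This is the same kind of change as from compound 1 to compound 2, but the place differs: there the methyl entered on a saturated chain carbon bound to two saturated chain carbons, here on a saturated chain carbon, six bonds along the chain from an oxygen on an aromatic ring. Within the data shown here, only the one earlier pair speaks to it. Given that compound 1 to compound 2 gave a 2.8-fold lower number from compound 1 to compound 2 (0.44 log units; beyond the scatter), a smaller step of a 1.5-fold lower number from compound 3 to compound 4 (0.16 log units; within the scatter) is expected here, since the place is not the same. Compound 4 is therefore estimated at 5000 nM, within 2000 nM to 12000 nM.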

Compound 4, half-maximal inhibitory concentration: 5700 nM
Estimate against measurement, compound 4: 1.1-fold (0.06 log units) below; measured number inside the range.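

In this assay, methyl in place of hydrogen on a saturated chain carbon, six bonds along the chain from an oxygen on an aromatic ring, gives a 1.3-fold lower number from compound 3 to compound 4 (0.11 log units; within the scatter), so this step does not separate the two compounds. Set beside the earlier methyl step, the new step shows no difference that can be told from measurement scatter: the same change on two cores in this assay, a 2.8-fold lower number (0.44 log units; beyond the scatter) from compound 1 to compound 2 and a 1.3-fold lower number (0.11 log units; within the scatter) from compound 3 to compound 4, 2.2-fold (0.33 log units) apart, within the scatter of two such steps. Among these compounds, this is consistent with the change carrying from one core to the other, but it does not establish a common size or even a common direction, since only two pairs are available, the methyl enters at different places, and only the earlier step lies beyond the scatter.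

The compounds shown leave open how a chain longer than that of compound 4 would read in this assay. They also leave open what an amine or a carboxylic acid would do in place of the methyl that enters in compound 4.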